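The source may report more compounds than this note shows. Statements on the series, on what has been measured and on what is new or still open speak of the compounds shown alone.

Working notes on the thiocarbamate series sharing the benzamide core of compound 1 `Nc1ccccc1NC(=O)c1ccc(CSC(=S)N2CCN(C3CCCCC3)CC2)cc1`. In a functional assay on MGC-803 cells (Homo sapiens) for antiproliferative activity, read by CCK-8 assay, with a stated time of 72 h, tested at 2 uM (a lower number here means a weaker effect, a higher number a stronger effect of the compound at the concentration tested), compound 1 gives 16.9%, the lowest of the three numbers in hand. Compound 2 `Nc1ccccc1NC(=O)c1ccc(CSC(=S)N2CCc3cc([N+](=O)[O-])ccc32)cc1` gives 26.8% in this assay, a number within the usual scatter of that of compound 1, so no order between the two is read. Compound 3 `Nc1ccccc1NC(=O)c1ccc(CSC(=S)N2CCc3ccc([N+](=O)[O-])cc32)cc1` gives 30.6% in this assay, and its gap to compound 1 lies beyond the scatter. For the measured compounds named here, compounds 2 and 3 carry a different amine on the thiocarbamate than compound 1 and are not single-point neighbours of it, so no step between them and compound 1 is computed here.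

Compound 4 `N#Cc1ccc(N2CCN(C(=S)SCc3ccc(C(=O)Nc4ccccc4N)cc3)CC2)cc1` is the unmeasured analogue. It differs from compound 1 as follows: 4-cyanophenyl in place of cyclohexyl on an amine nitrogen in a ring. Going by the values given here, no pair of measured compounds shows this change, so the size of the step is a judgement. With compound 1 at 16.9% and compound 3 at 30.6%, only a modest rise is expected, and the step of a number 10.1 percentage points higher from compound 1 to compound 4 (beyond the scatter) is estimated to sit near the edge of the scatter. For compound 4 the expected value in this assay is 27%, with a range from 14% to 42%.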

Compound 4, a percentage reported as inhibition, at one concentration (the size of the read-out at that concentration, not a potency): 34.5%
For compound 4 the middle estimate is 7.5 percentage points below the measured one, and the stated range covers the measured number.
By their numbers in this assay, from the lowest: compounds 1, 2, 3 and 4 (each within the scatter of the next, the first and the last beyond it).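

In this assay, for the compounds shown here, 4-cyanophenyl in place of cyclohexyl gives a number 17.6 percentage points higher from compound 1 to compound 4 (beyond the scatter), the first step that can be read at a single place, so the group on this amine nitrogen in a ring does register in the read-out. The change brings in an aromatic ring and a nitrile together, replacing a non-aromatic ring of carbon only, and this one step cannot separate the share of each. Nothing in hand gives a reason for the step.

The compounds shown leave open how much of the step would remain with an unsubstituted phenyl, and whether a pyridyl or a benzyl on the same nitrogen would read closer to compound 4 or to compound 1. Compounds 2 and 3 differ from compound 4 in more than one place and do not settle this.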